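The compounds below may be only part of what the source reports. "The series", "measured", "known", "first", "only" and "open" are said of these compounds alone.

Measured compounds in a functional assay on cells (Leukemia cell, Homo sapiens) for cytotoxicity, read by sulforhodamine B assay, with a stated time of 48 h; on this read-out higher numbers stand for weaker inhibition of growth and lower numbers for stronger inhibition of growth:

- compound 1 `CN(C)c1ccc(C2CC(c3ccccc3)=NN2C2=NC(=O)/C(=C3\C(=O)Nc4ccccc43)S2)cc1`, measured at 33900 nM
- compound 2 `CN(C)c1ccc(C2CC(c3ccccc3)=NN2C2=NC(=O)/C(=C3\C(=O)Nc4ccc(Br)cc43)S2)cc1`, measured at 310 nM

Compound 2 stands at the lower of the two numbers in this assay; its nearest neighbour is compound 1, and the step of a 110-fold lower number from compound 1 to compound 2 (2.04 log units; beyond the scatter) separates them. For the measured compounds named here, that step, bromo in place of hydrogen on an aromatic carbon, is the only measured change, and it is large.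

Compound 3 `CN(C)c1ccc(C2CC(c3ccccc3)=NN2C2=NC(=O)/C(=C3\C(=O)Nc4ccc(Cl)cc43)S2)cc1` is not yet measured. It differs from compound 2 by chloro in place of bromo on an aromatic carbon. Going by the values given here, no measured pair bears directly on a swap of one halogen for another; the single step on record concerns the presence of a halogen at that position against none. With bromo present in compound 2 at 310 nM, the replacement by chloro is expected to move the number only a little, and the step of a 1.6-fold higher number from compound 2 to compound 3 (0.21 log units; within the scatter) is estimated to lie within the usual scatter, if anything towards a slightly higher number. Compound 3 is therefore expected near 500 nM, with a range from 150 nM to 2000 nM.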

Compound 3, concentration for 50% growth inhibition: 340 nM
For compound 3 the middle estimate is 1.5-fold (0.17 log units) above the measured one; measured number inside the range.
By their numbers in this assay, from the lowest: compounds 2 and 3 (each within the scatter of the next); then compound 1.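

In this assay, chloro in place of bromo on the aromatic carbon gives a 1.1-fold higher number from compound 2 to compound 3 (0.04 log units; within the scatter) and so does not separate the two halogens at this position on this read-out. Measured against hydrogen at the same carbon, chloro gives a 100-fold lower number from compound 1 to compound 3 (2.00 log units; beyond the scatter) and thus a second large step, which shows that the large step seen with bromo is not unique to bromo among the groups tested. The series now links both chloro and bromo at this carbon to the stronger inhibition of growth, but no supporting data are available to explain the link.

Whether a halogen is needed at all remains open, as the compounds shown carry only hydrogen, chloro or bromo at this carbon, and fluoro, methyl, methoxy, a nitrile or a carboxylic acid there would test how far the large step extends beyond these two halogens. Also open, on these data alone, are whether chloro or bromo would give a similar step on another carbon of the same ring, and whether either step would carry over to cells of another type.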